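This account rests on a few compounds, and the source may have more. Where it says the series, first, only, none or still open, it means among the compounds named here.

Measured in an ADME assay on microsomes from liver (Homo sapiens) for metabolic stability, read by LC-MS, with NADPH named in the record, with a stated time of 60 min, tested at 1 uM, in the absence of a further agent; on this read-out lower numbers stand for a less stable compound and higher numbers for a more stable compound:
- Compound 1 `COc1ccc(-c2c(C)nc3c(N4CC[C@@H](NS(C)(=O)=O)C4)cc(C)nn23)cc1OC`: > 95%
- Compound 2 `COc1ccc(-c2c(C)nc3c(N4CC[C@@H](NS(=O)(=O)c5ccccc5)C4)cc(C)nn23)cc1OC`: > 95%
- Compound 3 `COc1ccc(-c2c(C)nc3c(N4CC=CC4)cc(C)nn23)cc1OC`: > 95%

Each of these entries is a limit of the assay and not a number.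

As far as these compounds go, compound 3 gives > 95%, so its exact place on the scale is unknown. The other two compounds stand no differently: the limit of > 95% in this assay, at which 3 of the 3 values shown sit.

The next compound is compound 4 `COc1ccc(-c2c(C)nc3c(N4CC[C@@H](SC(C)=O)C4)cc(C)nn23)cc1OC`. The change is a group of 9 heavy atoms (6 carbon, 1 nitrogen, 1 oxygen, 1 sulfur; one five-membered non-aromatic ring with 1 hetero atom) in place of a group of 5 heavy atoms (4 carbon, 1 nitrogen; one five-membered non-aromatic ring with 1 hetero atom), on an aromatic carbon. In words, a 3-(acetylsulfanyl)pyrrolidin-1-yl group enters on the same aromatic carbon, opposite the ring nitrogen, while the rest of the molecule stays the same.

Within the data shown here, two measured steps bear on this. The first, a step that the two limits leave unreadable from compound 1 to compound 2, alters the group on the sulfonyl sulfur. The second, a step that the two limits leave unreadable from compound 1 to compound 3, exchanges groups on the aromatic carbon that changes here, which makes it the closer guide. Neither step has a readable size, so neither gives a measure of how far this kind of change can move the read-out. Among the measured compounds shown here, no measured compound carries the acetylsulfanyl group.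

The expectation is therefore no step beyond the usual scatter, held with limited confidence, and any real step would be expected to run towards less stable. The estimated step is a number at least 5 percentage points lower from compound 3 to compound 4 (that floor lies within the scatter). For compound 4 the expected value is 90%, with an estimated range from 65% to 100%.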

Compound 4, percent of the compound remaining: > 95%
Compound 4 was reported as a limit; the forecaster's own chance of this, stated with the estimate: 50%; middle value at least 5 percentage points away from the limit.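

In this assay compound 4 gives > 95%, a limit of the assay and not a number. Its steps from compound 1, compound 2 and compound 3 therefore cannot be read, and all the compounds stand at the same mark: the limit of > 95% in this assay, at which 4 of the 4 values shown sit.

The compounds shown leave open whether any of these groups changes the percent remaining at all, and by how much.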